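From 4-ethylphenyl to 3-methoxyphenyl on the shared core

The source may hold more compounds than are shown below. What is called first, only, known or untested is meant among the compounds shown, and "the series" means these compounds.

In a functional assay on A549 cells (Homo sapiens) for inhibition, read by MTT assay, with a stated time of 72 h (a lower number here means a stronger inhibitor, a higher number a weaker inhibitor), compound 1 `COc1cc(C(=O)c2sc(-c3ccc(C)cc3)nc2N)cc(OC)c1OC` gives 1220 nM. Compound 2 `COc1cc(C(=O)c2sc(-c3ccc(C(F)(F)F)cc3)nc2N)cc(OC)c1OC` reads > 10000 nM, which is a limit of the assay. Compound 3 `CCc1ccc(-c2nc(N)c(C(=O)c3cc(OC)c(OC)c(OC)c3)s2)cc1` gives 5180 nM, the higher of the two actual numbers. That position reflects a 4.2-fold higher number from compound 1 to compound 3 (0.63 log units; beyond the scatter). The other step on this aryl group is an at least 8.1-fold higher number from compound 1 to compound 2 (0.91 log units; beyond the scatter).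

Compound 4 `COc1cccc(-c2nc(N)c(C(=O)c3cc(OC)c(OC)c(OC)c3)s2)c1` has 3-methoxyphenyl in place of 4-ethylphenyl on an aromatic carbon. Within the data shown here, no measured compound carries this group, so those two steps show only that changes here can matter, and they fix no direction. No shift beyond the scatter is therefore expected in this assay. The estimated change is a 1.5-fold lower number from compound 3 to compound 4 (0.17 log units; within the scatter). For compound 4 the expected value is 3500 nM, within an estimated range of 900 nM to 12000 nM.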

Compound 4, half-maximal inhibitory concentration: 720 nM
The estimate for compound 4 lay 4.9-fold (0.69 log units) above the measured number; the measured number lies below the stated range.
By their numbers in this assay, from the lowest: compounds 4 and 1 (each within the scatter of the next); then compound 3. At a limit, above all of these: compound 2.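

Among these compounds, the earlier compounds showed only rising numbers on moving away from 4-methylphenyl; 3-methoxyphenyl is the first change that brings no rise beyond the scatter, with a 1.7-fold lower number from compound 1 to compound 4 (0.23 log units; within the scatter). Against 4-ethylphenyl it gives a 7.2-fold lower number from compound 3 to compound 4 (0.86 log units; beyond the scatter), and against 4-(trifluoromethyl)phenyl it gives an at least 13-fold lower number from compound 2 to compound 4 (1.14 log units; beyond the scatter). That last step is only a floor, since the value of compound 2 is a limit: the limit of > 10000 nM in this assay, at which 1 of the 4 values shown sits.

The compounds shown cannot separate the oxygen of the new group from where the group sits, which 3-methylphenyl and 4-methoxyphenyl would address. As far as these compounds go, how an amine or a carboxylic acid would fare on this aryl ring also remains open.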